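Compound 1 to compound 4: propyl for 4-methylphenyl

A few compounds are considered here, and "the series" means these few. Any claim that something is new, unique, unknown or untested is made for them only; others in the source may bear on it.

In a functional assay on PC-3 cells (Homo sapiens) for cytotoxicity, read by WST assay, with a stated time of 72 h (on this read-out higher numbers stand for weaker inhibition and lower numbers for stronger inhibition), compound 1 `Cc1ccc(C2(c3ccc(O)cc3)C(=O)Nc3c2ccc(F)c3F)cc1` gives 0.8 nM, the lowest number of the series, and compound 3 `COc1ccc(C2(c3cccc(O)c3)C(=O)Nc3c2ccc(F)c3F)cc1` gives a higher 145 nM. Compound 2 `CCCCCOc1ccc(C2(c3ccc(O)cc3)C(=O)Nc3c2ccc(F)c3F)cc1` reaches only a limit of the assay, > 1000 nM. Compound 4 `CCCC1(c2ccc(O)cc2)C(=O)Nc2c1ccc(F)c2F` carries propyl in place of 4-methylphenyl on a saturated ring carbon. Among the measured compounds shown here, no measured step removes this whole aryl group. The nearest evidence is a change within that same group, an at least 1200-fold higher number from compound 1 to compound 2 (3.09 log units; beyond the scatter), a large step that rests on the limit (the limit of > 1000 nM in this assay, at which 1 of the 3 values shown sits). A rise of clear size is therefore expected, though its extent is uncertain. The expected step is a 50-fold higher number from compound 1 to compound 4 (1.70 log units; beyond the scatter), towards weaker inhibition. For compound 4 the estimated value is 40 nM, with an expected range of 3 nM to 500 nM.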

Compound 4, half-maximal inhibitory concentration: > 1000 nM
Compound 4: only a limit was reported; the forecaster's own chance of this, stated with the estimate: 15%; middle value at least 25-fold (1.39 log units) away from the limit.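

In this assay, the aromatic ring at this saturated ring carbon proves necessary for the low number, at least when propyl replaces it: the change gives an at least 1200-fold higher number from compound 1 to compound 4 (3.09 log units; beyond the scatter). Earlier, only a substituent on this aryl group had changed, whereas this step removes the ring itself. Compound 4 and compound 2 both sit at a limit, so they cannot be ranked, and the step is only a bound: the limit of > 1000 nM in this assay, at which 2 of the 4 values shown sit.

Still open, on these data alone, is whether a plain phenyl, a pyridyl or a cyclohexyl at this carbon would keep a number close to that of compound 1.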